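This account rests on a few compounds, and the source may have more. Where it says the series, first, only, none or still open, it means among the compounds named here.

Measured so far in a functional assay on HeLa cells (Homo sapiens) for antiproliferative activity, read by CCK-8 assay, with a stated time of 72 h, tested at 8 uM; on this read-out lower numbers stand for a weaker effect and higher numbers for a stronger effect at the one concentration tested:
- compound 1 `Nc1ccccc1NC(=O)c1ccc(CSC(=S)N2CCN(Cc3ccccn3)CC2)cc1` gives 61.4%
- compound 2 `Nc1ccccc1NC(=O)c1ccc(CSC(=S)N2CCN(C(c3ccccc3)c3ccccc3)CC2)cc1` gives 13.8%

The two measured compounds share the core and differ only in the group on the amine nitrogen of the six-membered ring with two nitrogens. Compound 1 stands highest of the two numbers; the nearest, compound 2, lies lower by a gap beyond the scatter, so the smaller (pyridin-2-yl)methyl group goes with the stronger effect in this assay and the diphenylmethyl group with a much weaker one.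

Compound 3 `Nc1ccccc1NC(=O)c1ccc(CSC(=S)N2CCN(c3ccc(Cl)cc3)CC2)cc1` has not been measured in this assay. It differs from compound 1 as follows: 4-chlorophenyl in place of (pyridin-2-yl)methyl on an amine nitrogen in a ring. The change removes the one hydrogen-bond acceptor of the leaving group and places an aromatic ring directly on the ring nitrogen. Within the data shown here, no step between measured compounds covers this change. A downward step of moderate size, likely beyond the scatter but much smaller than the drop to compound 2, is expected.

For compound 3 the expected value in this assay is 40%, with a range from 15% to 65%. This estimate corresponds to an expected step of a number 21.4 percentage points lower from compound 1 to compound 3 (beyond the scatter).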

Compound 3, a percentage reported as inhibition, at one concentration (the size of the read-out at that concentration, not a potency): 44.8%
For compound 3 the middle estimate is 4.8 percentage points below the measured one; measured number inside the range.
By their numbers in this assay, from the lowest: compound 2; then compound 3; then compound 1.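

In this assay, replacing (pyridin-2-yl)methyl with 4-chlorophenyl on the amine nitrogen in the ring gives a number 16.6 percentage points lower from compound 1 to compound 3 (beyond the scatter), a modest step that shows this position keeps a clear effect with an aromatic ring of carbon only, set directly on the nitrogen and carrying no hydrogen-bond acceptor. Compound 3 at 44.8% still stands well clear of compound 2 at 13.8%, so among these three groups a large loss goes with diphenylmethyl alone, while the pyridine nitrogen of compound 1 is not required for a sizeable effect at the one concentration tested. Nothing at hand on the compounds themselves accounts for the size of this step.

The step combines three changes that remain unseparated: loss of the ring nitrogen, loss of the one-carbon link to the ring, and arrival of the chlorine. Benzyl and unsubstituted phenyl on the same nitrogen would divide these contributions, and a pyridin-2-yl group set directly on that nitrogen would show whether the ring nitrogen still counts without the link.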